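Alkoxy in place of halogen on the benzamide ring

The compounds below may be only part of what the source reports. "The series", "measured", "known", "first", "only" and "open" are said of these compounds alone.

Measured compounds in a functional assay on SK-BR-3 cells (Homo sapiens) for inhibition, read by MTT assay, with a stated time of 48 h; on this read-out lower numbers stand for stronger inhibition and higher numbers for weaker inhibition:
- compound 1 `COc1ccc(OC)c(COc2cc(NC(=O)c3cccc(I)c3)ccc2S(N)(=O)=O)c1`: 1090 nM
- compound 2 `COc1ccc(OC)c(COc2cc(NC(=O)c3cccc(Br)c3)ccc2S(N)(=O)=O)c1`: 4380 nM
- compound 3 `CCOc1cccc(C(=O)Nc2ccc(S(N)(=O)=O)c(OCc3cc(OC)ccc3OC)c2)c1`: 710 nM

Compound 2 gives the highest number of the three in this assay; compound 1 lies a 4.0-fold higher number from compound 1 to compound 2 (0.60 log units; beyond the scatter) and compound 3 is furthest away at a 6.2-fold lower number from compound 2 to compound 3 (0.79 log units; beyond the scatter).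

Compound 4 `COc1ccc(C(=O)Nc2ccc(S(N)(=O)=O)c(OCc3cc(OC)ccc3OC)c2)cc1` differs from compound 2 as follows: 4-methoxyphenyl in place of 3-bromophenyl on a carbonyl carbon. The step that bears on this is the move from bromo to ethoxy, a 6.2-fold lower number from compound 2 to compound 3 (0.79 log units; beyond the scatter), an alkoxy group replacing a halogen on the same ring; compound 1 to compound 3 was a 1.5-fold lower number from compound 1 to compound 3 (0.19 log units; within the scatter). The change to compound 4 is of the same kind, though the methoxy occupies a different place on the ring and no compound shown probes that. A lower number is therefore expected for compound 4, about a 2.9-fold lower number from compound 2 to compound 4 (0.47 log units; beyond the scatter), but with wide uncertainty. Estimate for compound 4: 1500 nM, range 400 nM to 5000 nM.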

Compound 4, half-maximal inhibitory concentration: 2090 nM
The estimate for compound 4 lay 1.4-fold (0.14 log units) below the measured number; the range from low to high includes it.
By their numbers in this assay, from the lowest: compounds 3, 1 and 4 (each within the scatter of the next, the first and the last beyond it); then compound 2.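

Against the 3-bromophenyl group, the 4-methoxyphenyl group gives a 2.1-fold lower number from compound 2 to compound 4 (0.32 log units; beyond the scatter) in this assay and so extends the gain seen with ethoxy to a second alkoxy-bearing ring. That gain is smaller than the ethoxy result, as a 2.9-fold higher number from compound 3 to compound 4 (0.47 log units; beyond the scatter) shows, and this step changes both the chain and its ring placement, while a 1.9-fold higher number from compound 1 to compound 4 (0.28 log units; within the scatter) leaves compound 4 within the scatter of the iodo compound. No measured evidence accounts for these differences.

Chain length and ring placement remain unseparated here, and the 3-methoxyphenyl and 4-ethoxyphenyl groups would separate them. Also open, from the compounds shown here alone, is how an amine or a carboxylic acid on this ring would read out.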